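The source may hold more compounds than are shown below. What is called first, only, known or untested is meant among the compounds shown, and "the series" means these compounds.

Working notes on the series, read in an ADME assay on HEp-2 cells (Homo sapiens) for cytotoxicity, read by MTT assay, with a stated time of 72 h; on this read-out lower numbers stand for stronger inhibition and higher numbers for weaker inhibition. Compound 1 `COc1ccc(C2=C(c3cc(OC)c(OC)c(OC)c3)C(=O)CC2C)cc1C(=O)O` gives > 100 ug/mL, which is a limit of the assay and not a number. Compound 2 `C=CCOc1cc(C2=C(c3cc(OC)c(OC)c(OC)c3)C(=O)C(O)C2)ccc1OC` gives > 100 ug/mL, which is also a limit and not a number. The evidence so far therefore amounts to the limit of > 100 ug/mL in this assay, at which 2 of the 2 values shown sit, and compound 2 has no measured position within the range of the assay.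

Compound 3 `COc1ccc(C2=C(c3cc(OC)c(OC)c(OC)c3)C(=O)C(O)C2)cc1Cl` carries chloro in place of allyloxy on an aromatic carbon, ortho to a methoxy group and meta to a large group: chloro in place of allyloxy on an aromatic carbon. Going by the values given here, no measured pair differs in one place, so the data give no size for such a change. The expected change, an at least 1.6-fold lower number from compound 2 to compound 3 (0.22 log units; that floor lies within the scatter), is toward stronger inhibition, though a result again at the limit in this assay is about as likely. The estimate for compound 3 is an expected 60 ug/mL, within an expected range of 8 ug/mL to 200 ug/mL.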

Compound 3, half-maximal inhibitory concentration: < 1 ug/mL
Compound 3 gave a limit, no number (the forecaster's own chance of this, stated with the estimate: 50%); middle value at least 60-fold (1.77 log units) from the limit.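

In this assay compound 3 gives < 1 ug/mL, a limit and not a number. Going by these compounds alone, the first step that can be read is chloro in place of allyloxy on an aromatic carbon, ortho to a methoxy group and meta to a large group, with an at least 100-fold lower number from compound 2 to compound 3 (2.00 log units; beyond the scatter), which shows that the read-out responds strongly to what this position carries. Both ends of that step are limits, so it gives a floor for the size of the change and no exact size.

As far as these compounds go, whether the shift belongs to the arrival of chloro or to the departure of allyloxy stays open, with only these two groups compared at this carbon. A fluoro, a hydroxyl, an amine or a longer chain at the same carbon would separate these two readings.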